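This account rests on a few compounds, and the source may have more. Where it says the series, first, only, none or still open, it means among the compounds named here.

Compound 2 `O=C(c1cc2ccccc2[nH]1)N1CCC(NCCSC(c2ccc(F)cc2)c2ccc(F)cc2)CC1` carries an (1H-indol-2-yl)carbonyl on an amine nitrogen in a ring, and in an assay on membranes from striatum (strain Sprague-Dawley) for displacement of a labelled ligand from sodium-dependent dopamine transporter (Rattus norvegicus), read by scintillation counting, with a stated time of 120 min (on this read-out lower numbers stand for stronger inhibition and higher numbers for weaker inhibition), compound 2 gives 177 nM, the highest of the two numbers in hand. Going by the values given here, its only measured neighbour is compound 1 `Fc1ccc(CN2CCC(NCCSC(c3ccc(F)cc3)c3ccc(F)cc3)CC2)cc1`, which in this assay gives 25.5 nM; the step of a 6.9-fold higher number from compound 1 to compound 2 (0.84 log units; beyond the scatter) shows the cost of putting the (1H-indol-2-yl)carbonyl in for 4-fluorobenzyl. Compound 3 `Fc1ccc(C(SCCNC2CCN(Cc3cc4ccccc4o3)CC2)c2ccc(F)cc2)cc1` moves away again: (1-benzofuran-2-yl)methyl in place of (1H-indol-2-yl)carbonyl on an amine nitrogen in a ring. Among the compounds with values here, the entering group, like the 4-fluorobenzyl of compound 1, has no double bond outside aromatic rings and no hydrogen-bond donor, so the one step that bears on this change is expected to run largely in reverse. Compound 3 is therefore expected to show a 5.1-fold lower number from compound 2 to compound 3 (0.70 log units; beyond the scatter), a lower number beyond the scatter, with an estimate of 35 nM in a range from 12 nM to 110 nM.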

Compound 3, inhibition constant: 120 nM
Estimate against measurement, compound 3: 3.4-fold (0.54 log units) below, outside the stated range (above it).
By their numbers in this assay, from the lowest: compound 1; then compounds 3 and 2 (each within the scatter of the next).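

Replacing the (1H-indol-2-yl)carbonyl with (1-benzofuran-2-yl)methyl on this amine nitrogen in a ring removes the double bond outside aromatic rings and the hydrogen-bond donor, yet in this assay it gives a 1.5-fold lower number from compound 2 to compound 3 (0.17 log units; within the scatter). Losing these two features therefore does not by itself restore the number of compound 1, and the step of a 4.7-fold higher number from compound 1 to compound 3 (0.67 log units; beyond the scatter) shows that a group without them can still cost affinity, so among these three compounds the two entries with a five-membered and a six-membered aromatic ring stand together, apart from the 4-fluorobenzyl. No measured evidence explains this outcome. From the compounds shown here alone, what remains open is whether a (1H-indol-2-yl)methyl or a 4-fluorobenzoyl group on the same nitrogen would follow the ring system or the carbonyl. A (1-benzofuran-2-yl)carbonyl group would put the same question from the other side.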